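Chloro in Place of Phenyl on the Benzylic Ring

A few compounds are considered here, and "the series" means these few. Any claim that something is new, unique, unknown or untested is made for them only; others in the source may bear on it.

Measured compounds in a functional assay on MCF7 cells (Homo sapiens) for inhibition, read by MTT assay, with a stated time of 72 h; on this read-out lower numbers stand for stronger inhibition of growth and higher numbers for weaker inhibition of growth:
- compound 1, `O=S(=O)(NCCCNCc1ccccc1Cl)c1cc(C(F)(F)F)cc(C(F)(F)F)c1`, gives 8800 nM
- compound 2, `O=S(=O)(NCCCNCc1ccc(C(F)(F)F)cc1)c1cc(C(F)(F)F)cc(C(F)(F)F)c1`, gives 1400 nM
- compound 3, `O=S(=O)(NCCCNCc1ccc(-c2ccccc2)cc1)c1cc(C(F)(F)F)cc(C(F)(F)F)c1`, gives 1700 nM

Compound 3 stands second highest of the three numbers. Its nearest neighbour is compound 2, and the two lie within the scatter of each other, as the step of a 1.2-fold higher number from compound 2 to compound 3 (0.08 log units; within the scatter) shows. The furthest is compound 1, a step beyond the scatter.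

Compound 4, `O=S(=O)(NCCCNCc1ccc(Cl)cc1)c1cc(C(F)(F)F)cc(C(F)(F)F)c1`, is not yet measured. It differs from compound 3 in one place: chloro in place of phenyl on an aromatic carbon.

Going by the values given here, two measured steps bear on this. The step of a 6.3-fold lower number from compound 1 to compound 2 (0.80 log units; beyond the scatter) shows that the group on the benzylic ring can move the number a good deal. The step of a 1.2-fold higher number from compound 2 to compound 3 (0.08 log units; within the scatter) shows that exchanging trifluoromethyl for phenyl at that position changed nothing beyond the scatter. A chloro group at the same position is expected to behave much like the trifluoromethyl of compound 2 or the phenyl of compound 3, so compound 4 is expected to show a step of a 1.2-fold higher number from compound 3 to compound 4 (0.07 log units; within the scatter), within the scatter. The estimate for compound 4 in this assay is 2000 nM, with a range from 800 nM to 5000 nM.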

Compound 4, concentration for 50% growth inhibition: 2400 nM
Compound 4: the middle estimate sits 1.2-fold (0.08 log units) below what was measured; low and high end bracket the measured number.
By their numbers in this assay, from the lowest: compounds 2, 3 and 4 (each within the scatter of the next); then compound 1.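

In this assay, this aromatic carbon takes chloro, with its 1 heavy atom, as readily as phenyl, with its 6: the exchange gives a 1.4-fold higher number from compound 3 to compound 4 (0.15 log units; within the scatter), and the exchange of trifluoromethyl for chloro gives a 1.7-fold higher number from compound 2 to compound 4 (0.23 log units; within the scatter), so the three groups cannot be told apart at this place. Going by these compounds alone, the last comparison adds what the earlier compounds could not show, since the step from 2-chlorophenyl to 4-chlorophenyl keeps the same group and changes only where it stands on the ring, and it gives a 3.7-fold lower number from compound 1 to compound 4 (0.56 log units; beyond the scatter), beyond the scatter. Nothing available explains this dependence on place or the lack of separation among the three groups.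

On these data alone, it remains open whether a carboxylic acid, a hydroxyl group or an amine on the same aromatic carbon would keep the number in the same range as chloro, trifluoromethyl and phenyl. As far as these compounds go, it is also open whether the same tolerance would hold with a longer chain in the shared core.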